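The source may report more compounds than this note shows. Statements on the series, on what has been measured and on what is new or still open speak of the compounds shown alone.

In a physicochemical assay for solubility, at pH 7.4 (on this read-out higher numbers stand for higher solubility and lower numbers for lower solubility), compound 1 (`CNC1CN(c2c(F)cc3c(=O)c(C(=O)O)cn(C4CC4)c3c2F)C1`) gives 1.7 ug/mL and compound 2 (`CC[C@H]1[C@@H](N)CN1c1cc2c(cc1F)c(=O)c(C(=O)O)cn2C1CC1`) gives 42.2 ug/mL as its reading. Among the compounds with values here, compound 1 therefore holds the lower of only two numbers, and its gap to compound 2 lies beyond the usual scatter of repeated measurements. These two compounds differ in more than one place, so their gap cannot be assigned to any single structural change. Compound 3 (`CN(C)C1CN(c2c(F)cc3c(=O)c(C(=O)O)cn(C4CC4)c3c2F)C1`) has not yet been measured. It differs from compound 1 in one place (methyl in place of hydrogen on an amine nitrogen), with methyl in place of hydrogen on an amine nitrogen, which turns 3-(methylamino)azetidin-1-yl into 3-(dimethylamino)azetidin-1-yl. Within the data shown here, no measured pair shows what this change does, so the expectation remains cautious and the range wide. A small upward step in this assay is expected, and it may not clear the scatter. The estimated step of a 1.8-fold higher number from compound 1 to compound 3 (0.25 log units; within the scatter) is of that modest size. Compound 3 is expected to read 3 ug/mL (from 1 ug/mL to 12 ug/mL) once it is measured.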

Compound 3, solubility: 58 ug/mL
For compound 3 the middle estimate is 19-fold (1.29 log units) below the measured one; the measured number lies above the stated range.
By their numbers in this assay, from the lowest: compound 1; then compounds 2 and 3 (each within the scatter of the next).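

In this assay, within the data shown here, putting methyl in place of hydrogen on the amine nitrogen gives a 34-fold higher number from compound 1 to compound 3 (1.53 log units; beyond the scatter) and so provides the first reading of a change made in one place. The step shows that this nitrogen, whose other neighbours are a saturated chain carbon and a saturated ring carbon, is a place where one added carbon can move the reading well beyond the scatter while the rest of the structure stays the same. No available measurement bears on the reason for this step.

The compounds shown leave open whether a longer chain such as ethyl on the same nitrogen would give a step of similar size, or whether an acetyl group there would move the reading at all. They also leave open whether methyl on the amine of compound 2 would have a similar effect, and so whether this step holds beyond the 3-(methylamino)azetidin-1-yl group.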